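The source may hold more compounds than are shown below. What is called first, only, known or untested is meant among the compounds shown, and "the series" means these compounds.

Compound 1 `N[C@H]1CC[C@H](Nc2c(C(=O)NCc3ccc(Cl)cc3)nc(Br)c3cccnc23)CC1` and compound 3 `N[C@H]1CC[C@H](Nc2c(C(=O)NCc3ccc(F)cc3)nc(Br)c3cccnc23)CC1` share one core and differ only in a halogen on the outer aromatic ring; compound 2 `N[C@H]1CC[C@H](Nc2c(C(=O)NCc3cccc(C(F)(F)F)c3)nc(Br)c3cccnc23)CC1` carries a trifluoromethyl group there instead. In a functional assay on HCT-116 cells (Homo sapiens) for cytotoxicity, read by MTT assay, with a stated time of 72 h (a higher number here means a weaker inhibitor, a lower number a stronger inhibitor), compound 1 gives 4000 nM, and compound 3 gives 7000 nM. For compound 2 the entry in this assay reads "not determined" (no result reported).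

Going by the values given here, the only complete step so far is a 1.8-fold higher number from compound 1 to compound 3 (0.24 log units; within the scatter), so the numbers of compound 1 and compound 3 lie within the scatter of each other, and nothing separates them with confidence.

Compound 4 `N[C@H]1CC[C@H](Nc2c(C(=O)NC3CCCCC3)nc(Br)c3cccnc23)CC1` takes a larger step away from compound 3: cyclohexyl in place of 4-fluorobenzyl on an amide-type nitrogen. Among the compounds with values here, the one measured step concerns a halogen swap on the aromatic ring and says nothing about removing the aromatic ring altogether, so no step on record bears directly on this change. With the whole outer group replaced, a move of some size in either direction is plausible, and a small loss of potency is taken as the more likely outcome, but the uncertainty is wide.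

For compound 4 the expected step is a 1.4-fold higher number from compound 3 to compound 4 (0.15 log units; within the scatter). The estimate for compound 4 in this assay is 10000 nM, with a range from 3000 nM to 40000 nM.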

Compound 4, half-maximal inhibitory concentration: > 10000 nM
Compound 4 gave a limit, no number; the forecaster's own chance of this, stated with the estimate: 20%; the middle value lies on the limit itself.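

In this assay compound 4 is reported only as a limit, not as a number: the limit of > 10000 nM in this assay, at which 1 of the 4 values shown sits. The earlier compounds shown here changed only a substituent on the outer aromatic ring, whereas here the whole 4-fluorobenzyl or 4-chlorobenzyl group gives way to cyclohexyl on the amide-type nitrogen, and the two comparisons read differently: an at least 1.4-fold higher number from compound 3 to compound 4 (0.15 log units; that floor lies within the scatter) stays inside the usual scatter at its floor, while an at least 2.5-fold higher number from compound 1 to compound 4 (0.39 log units; beyond the scatter) already goes beyond it. So this position does respond to replacing the benzyl group with a non-aromatic ring, at least against compound 1, and neither comparison shows any gain in potency from cyclohexyl.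

As far as these compounds go, the true size of both steps remains open, since only their floors can be read, so compound 4 may be only slightly weaker than compound 3 or far weaker. Also open, from the compounds shown here alone, is whether the aromatic ring itself matters or the way the ring is attached to the nitrogen, a question that a cyclohexylmethyl group at this place could help to separate from the benzyl compounds.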